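Stereochemical inversion on a benzyl-protected sugar-like core

A few compounds are considered here, and "the series" means these few. Any claim that something is new, unique, unknown or untested is made for them only; others in the source may bear on it.

Measured so far:
compound 1 `O[C@H]1CO[C@H](COCc2ccccc2)[C@@H](OCc2ccccc2)[C@@H]1OCc1ccccc1` — "not active" (no number reported)
compound 2 `CCC[C@@H]1O[C@H](COCc2ccccc2)[C@@H](OCc2ccccc2)[C@H](OCc2ccccc2)[C@H]1O` — 11700 nM
compound 3 `CC(C)C[C@H]1O[C@H](COCc2ccccc2)[C@H](OCc2ccccc2)[C@H](OCc2ccccc2)[C@H]1O` — "not active" (no number reported)

In a functional assay on HL-60 cells (Homo sapiens) for antiproliferative activity, read by MTT assay (a lower number here means a stronger inhibitor, a higher number a weaker inhibitor), compound 2 gives 11700 nM, a weak result. Compound 1 and compound 3 were reported only as not active, with no number attached, so neither can be placed on the same scale as compound 2. Compound 3 therefore stands without a single number, and one further entry in the set, compound 1, is in the same position. For the measured compounds named here, no direct step between two measured compounds can be drawn here, since no pair differs in one place only.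

Compound 4 `CC(C)C[C@@H]1O[C@H](COCc2ccccc2)[C@@H](OCc2ccccc2)[C@H](OCc2ccccc2)[C@H]1O` is the next entry. Relative to compound 3: the two compounds have the same atoms and bonds and differ only in configuration as drawn: 2 of 5 stereo elements differ; a stereocentre at a saturated ring carbon is drawn R in compound 3 and S in compound 4; a stereocentre at a saturated ring carbon is drawn S in compound 3 and R in compound 4

Going by the values given here, with no measured step to lean on, the expected size of the change in this assay cannot be derived from the data; the only reference point with a number is compound 2, which sits at 11700 nM and carries a different chain. The working expectation is that compound 4 stays in the weak range, with a real chance that it too comes back without a number.

Compound 4 is estimated at 15000 nM in this assay, with a range from 4000 nM to 60000 nM.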

Compound 4, half-maximal inhibitory concentration: 8500 nM
Estimate against measurement, compound 4: 1.8-fold (0.25 log units) above; the range from low to high includes it.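

In this assay, compound 3 gives "not active" (no number reported) and compound 4 gives 8500 nM, so the series now holds a pair in which a number appears on one side only, and the two drawn stereocentres are the only thing separating that pair: the fact that compounds 3 and 4 differ only in the configuration as drawn Among the compounds shown, the configuration of compound 4 and compound 2 is therefore the one that carries a number, while the configuration of compound 3 does not, though two compounds are a thin basis for calling this a pattern. On the chain, methyl in place of hydrogen on a saturated chain carbon bound to two saturated chain carbons gives a 1.4-fold lower number from compound 2 to compound 4 (0.14 log units; within the scatter), so within this configuration the two chains cannot be told apart and the branch has no readable effect.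

As far as these compounds go, the size of the configuration effect stays open, since compound 3 has no number and the pair gives a direction only. Also open, from the compounds shown here alone, is whether a longer chain, or a chain ending in an amine, would move the value away from this weak range.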